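The compounds below may be only part of what the source reports. "The series", "measured", "known", "first", "only" and "open" are said of these compounds alone.

In a functional assay on PC-3 cells (Homo sapiens) for cytotoxicity, read by MTT assay (on this read-out higher numbers stand for weaker inhibition and lower numbers for stronger inhibition), compound 1 `COc1ccc(CSc2nnc([C@@H](C)c3ccc4cc(OC)ccc4c3)n2-c2ccc(Cl)cc2)cc1` is reported only as a limit, <= 400000 nM. Compound 2 `COc1ccc2cc([C@H](C)c3nnc(SCc4ccc(F)cc4)n3-c3ccc(Cl)cc3)ccc2c1` gives 10800 nM. Compound 3 `COc1ccc2cc([C@H](C)c3nnc(SCc4c(Cl)cccc4Cl)n3-c3ccc(F)cc3)ccc2c1` gives 216000 nM, the higher of the two actual numbers and beyond the scatter from compound 2. Compound 4 `COc1ccc2cc([C@H](C)c3nnc(SCc4c(Cl)cccc4Cl)n3-c3ccc(Cl)cc3)ccc2c1` differs from compound 3 by chloro in place of fluoro on an aromatic carbon, para to a large group. Among the compounds with values here, the only measured step, a step that the limit leaves unreadable from compound 1 to compound 2, cannot be read in size and is a different change. Within the data shown here, with no measured step to size this one, the expectation stays close to compound 3 at 216000 nM, with no shift beyond the scatter in this assay. The estimated step is a 1.4-fold lower number from compound 3 to compound 4 (0.16 log units; within the scatter). Compound 4 is expected at 150000 nM, with an estimated range of 40000 nM to 400000 nM.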

Compound 4, half-maximal inhibitory concentration: 34700 nM
Compound 4: middle estimate off by 4.3-fold (0.64 log units), on the high side, outside the stated range (below it).
By their numbers in this assay, from the lowest: compound 2; then compound 4; then compound 3.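

In this assay, the change from 4-fluorophenyl to 4-chlorophenyl with the 2,6-dichlorophenyl group held gives the first readable size at this position (a 6.2-fold lower number from compound 3 to compound 4 (0.79 log units; beyond the scatter)). With the 4-chlorophenyl group held, 2,6-dichlorophenyl in place of 4-fluorophenyl gives a higher number (a 3.2-fold higher number from compound 2 to compound 4 (0.51 log units; beyond the scatter)). As far as these compounds go, whether the chloro-for-fluoro step keeps its size with other groups on the sulfur-bound carbon stays open. So does the outcome with an amine or a carboxylic acid in place of the chloro. Compound 1 is reported only as a limit, and its steps cannot be read: the limit of <= 400000 nM in this assay, at which 1 of the 4 values shown sits.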